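The source may hold more compounds than are shown below. What is called first, only, known or untested is meant among the compounds shown, and "the series" means these compounds.

Compound 1 `O=C(/C=C/c1ccc(O)cc1)c1c(O)cccc1OCCC1CCCCC1`, compound 2 `CC(C)COc1cccc(O)c1C(=O)/C=C/c1ccc(O)cc1` and compound 3 `O=C(/C=C/c1ccc(O)cc1)c1c(O)cccc1OCc1ccccc1` share one core and differ only in the group on a saturated chain carbon bound to an oxygen on an aromatic ring. In a functional assay on NUGC-3 cells (Homo sapiens) for antiproliferative activity, read by sulforhodamine B assay (a lower number here means a stronger inhibitor of growth, a higher number a weaker inhibitor of growth), compound 1 gives > 30000 nM, which is a limit of the assay and not a number. Going by the values given here, compound 2 gives 2980 nM, the only true number available so far.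

Moving on to compound 3 puts phenyl in place of isopropyl at that carbon: phenyl in place of isopropyl on a saturated chain carbon bound to an oxygen on an aromatic ring. Among the compounds with values here, one measured step bears on this change: an at least 10-fold lower number from compound 1 to compound 2 (1.00 log units; beyond the scatter), with isopropyl in place of cyclohexylmethyl, which lies beyond the scatter. Of that pair, the compound carrying a ring is the weaker, and compound 3 brings a ring back, although an aromatic one. A single pair is thin evidence, so the rise expected in this assay is smaller than that step. The estimated change is a 2.0-fold higher number from compound 2 to compound 3 (0.30 log units; within the scatter), towards weaker growth inhibition. For compound 3 the expected value is 6000 nM, with an estimated range of 1800 nM to 22000 nM.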

Compound 3, concentration for 50% growth inhibition: > 30000 nM
Compound 3: a limit, no number (the forecaster's own chance of this, stated with the estimate: 20%); at least 5.0-fold (0.69 log units) between middle value and limit.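

In this assay, phenyl in place of isopropyl on this saturated chain carbon gives an at least 10-fold higher number from compound 2 to compound 3 (1.00 log units; beyond the scatter), a step beyond the scatter. The earlier step showed this loss of growth inhibition only for cyclohexylmethyl, a group with a saturated ring, whereas compound 3 shows that a group with an aromatic ring also ends far from compound 2, so among these three compounds only the one with no ring in this group gives a true number. The step between compound 1 and compound 3 cannot be read, so the two groups with rings cannot be ranked against each other, and any loss beyond the limit stays hidden: the limit of > 30000 nM in this assay, at which 2 of the 3 values shown sit.

Going by these compounds alone, what remains open is whether any group at this carbon does better than isopropyl, as compound 2, at 2980 nM, is the only compound here with a measured number to compare against. An amine, a hydroxyl or a plain ethyl group in place of isopropyl would test whether a smaller group or one with a polar atom moves the number in either direction.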